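A Change of Aryl Group on a Ring Amine Nitrogen

The compounds below may be only part of what the source reports. "The series", "measured", "known", "first", "only" and "open" are said of these compounds alone.

Compound 3 `COc1ccc(N2CCN(C(=S)N/N=C3\C(=O)Nc4ccc(Cl)cc43)CC2)cc1` gives 7680 nM in a functional assay on A549 cells (Homo sapiens) for inhibition, read by MTT assay, with a stated time of 72 h (on this read-out higher numbers stand for weaker inhibition and lower numbers for stronger inhibition), the lowest of the three numbers recorded. Compound 1 `O=C1Nc2ccccc2/C1=N/NC(=S)N1CCN(c2ccccc2)CC1` gives 18600 nM and compound 2 `O=C1Nc2ccc([N+](=O)[O-])cc2/C1=N/NC(=S)N1CCN(c2ccccc2)CC1` gives 17900 nM, and both of these gaps to compound 3 lie beyond the scatter. For the measured compounds named here, the only measured single step, a 1.0-fold lower number from compound 1 to compound 2 (0.02 log units; within the scatter), concerns the core itself and not the aryl group on the ring amine nitrogen. Compound 4 `Cc1ccccc1N1CCN(C(=S)N/N=C2\C(=O)Nc3ccc(Cl)cc32)CC1` differs from compound 3 by 2-methylphenyl in place of 4-methoxyphenyl on an amine nitrogen in a ring. Going by the values given here, no measured step bears on this change, so neither its direction nor its size can be read from the data. The step from compound 3 to compound 4 is therefore expected to be small, a 1.3-fold higher number from compound 3 to compound 4 (0.11 log units; within the scatter). Compound 4 is estimated at 10000 nM, with a range from 3000 nM to 30000 nM.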

Compound 4, half-maximal inhibitory concentration: 6520 nM
The estimate for compound 4 lay 1.5-fold (0.19 log units) above the measured number; the range from low to high includes it.
By their numbers in this assay, from the lowest: compounds 4 and 3 (each within the scatter of the next); then compounds 2 and 1 (each within the scatter of the next).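

In this assay, this first measured change of the aryl group on the amine nitrogen in the ring gives a 1.2-fold lower number from compound 3 to compound 4 (0.07 log units; within the scatter), so 2-methylphenyl in place of 4-methoxyphenyl does not separate the two compounds. At this position, then, one substituted phenyl can stand in for the other, even with a hydrogen-bond acceptor fewer, without a change beyond the scatter. Nothing available explains this result. Still open, from the compounds shown here alone, is how an amine or a carboxylic acid on this phenyl would read, and whether the same holds on the core of compound 1.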